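From 4-methoxyphenyl to phenyl in compound 4

A few compounds are considered here, and "the series" means these few. Any claim that something is new, unique, unknown or untested is made for them only; others in the source may bear on it.

Measured in a functional assay on A549 cells (Homo sapiens) for antiproliferative activity, read by MTT assay, with a stated time of 48 h; on this read-out higher numbers stand for weaker inhibition and lower numbers for stronger inhibition:
- compound 1 `COc1ccc(C(=O)Nc2nnc(/C=C/c3cc(OC)c(OC)c(OC)c3Br)s2)cc1`: 150 nM
- compound 2 `COc1ccc(/C=C/c2nnc(NC(=O)c3cc(OC)c(OC)c(OC)c3Br)s2)cc1`: 180 nM
- compound 3 `COc1cccc(/C=C/c2nnc(NC(=O)c3cc(OC)c(OC)c(OC)c3Br)s2)c1`: 190 nM

The three values lie within the usual scatter of one another, so compound 1 stands level with compound 2 and compound 3 in this assay.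

Compound 4 `COc1cc(/C=C/c2nnc(NC(=O)c3ccccc3)s2)c(Br)c(OC)c1OC` departs from compound 1 by a single change, hydrogen in place of methoxy on an aromatic carbon, para to a large group, so that 4-methoxyphenyl becomes phenyl. Going by the values given here, only one measured step bears on this, and only indirectly. That step, a 1.1-fold higher number from compound 2 to compound 3 (0.02 log units; within the scatter), moves a methoxy group from 4-methoxyphenyl to 3-methoxyphenyl and stays within the scatter. Among the compounds with values here, no measured pair shows a methoxy group being removed, so the expectation is uncertain. A step beyond the scatter is not expected, though a slightly higher number seems more likely than a lower one. The expected step is a 1.5-fold higher number from compound 1 to compound 4 (0.17 log units; within the scatter). For compound 4 the estimated value is 220 nM, with an expected range of 90 nM to 550 nM.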

Compound 4, half-maximal inhibitory concentration: 110 nM
The estimate for compound 4 lay 2.0-fold (0.30 log units) above the measured number, within the range that was stated.
By their numbers in this assay, from the lowest: compounds 4, 1, 2 and 3 (each within the scatter of the next).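

Taking the methoxy group off altogether, so that 4-methoxyphenyl becomes phenyl, gives a 1.4-fold lower number from compound 1 to compound 4 (0.13 log units; within the scatter) in this assay. The earlier compounds had only shown a methoxy group moved from one ring carbon to another, whereas this step shows that, on the core of compound 1, the hydrogen can stand in place of methoxy on this aromatic carbon, para to a large group, with the number staying within the scatter. Nothing shown accounts for this outcome.

The compounds shown leave open whether a hydroxy group, a chlorine atom or an amine on this same carbon would give a step beyond the scatter. They also leave open whether the same exchange would read alike on the core of compound 2, where the 4-methoxyphenyl group sits on the double-bonded chain.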